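Swapping One Side Chain for Another on a Shared Core

The source may report more compounds than this note shows. Statements on the series, on what has been measured and on what is new or still open speak of the compounds shown alone.

Compound 3 `CN(C)C(=O)c1cc2cnc(Nc3ccc(C(=O)NCCCCCN=C=S)cc3)nc2n1C1CCCC1` is the lowest of three numbers in a functional assay on A549 cells (Homo sapiens) for inhibition, read by CCK-8 assay, with a stated time of 72 h, tested at 10 uM (on this read-out higher numbers stand for a stronger effect at the one concentration tested and lower numbers for a weaker effect), where compound 3 gives 100%. Its nearest neighbour is compound 1 `CN(C)C(=O)c1cc2cnc(Nc3ccc(S(=O)(=O)NCCCN=C=S)cc3)nc2n1C1CCCC1`, which gives 102%, and the step of a number 2 percentage points lower from compound 1 to compound 3 (within the scatter) is small; compound 2 `CN(C)C(=O)c1cc2cnc(Nc3ccc(C(=O)NCCCN=C=S)cc3)nc2n1C1CCCC1` gives 103%, and the step of a number 3 percentage points lower from compound 2 to compound 3 (within the scatter) is also small, so all three sit together.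

Compound 4 `CN(C)C(=O)c1cc2cnc(Nc3ccc(NC(=O)CCCN=C=S)cc3)nc2n1C1CCCC1` carries a different side chain: a group of 9 heavy atoms (5 carbon, 2 nitrogen, 1 oxygen, 1 sulfur; no ring) in place of a group of 11 heavy atoms (7 carbon, 2 nitrogen, 1 oxygen, 1 sulfur; no ring), on an aromatic carbon.

Every measured step changes this same side chain, and each stayed flat: a number 1 percentage points higher from compound 1 to compound 2 (within the scatter), a number 2 percentage points lower from compound 1 to compound 3 (within the scatter) and a number 3 percentage points lower from compound 2 to compound 3 (within the scatter). Hence no shift beyond the scatter is expected in this assay for compound 4.

Compound 4 is therefore estimated at 100%, expected between 88% and 106%. The expected step is no change at the digits printed from compound 3 to compound 4 (within the scatter).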

Compound 4, a percentage reported as inhibition, at one concentration (the size of the read-out at that concentration, not a potency): 102%
Estimate against measurement, compound 4: 2 percentage points below, and the stated range covers the measured number.
By their numbers in this assay, from the lowest: compounds 3, 1, 4 and 2 (each within the scatter of the next).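

In this assay, turning the amide round, so that its nitrogen rather than its carbonyl sits on the aromatic carbon, gives a number 1 percentage points lower from compound 2 to compound 4 (within the scatter) and keeps the same heavy-atom count. The other comparisons give a number 2 percentage points higher from compound 3 to compound 4 (within the scatter) and no change at the digits printed from compound 1 to compound 4 (within the scatter), so among these compounds this position accepts the reversed linkage as well as the earlier side-chain changes. No evidence is available to explain this flat result. All four compounds were read at a single concentration, which leaves any differences in potency unresolved. On these data alone, whether a side chain ending in an amine or a carboxylic acid would hold this level also remains open.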